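This account rests on a few compounds, and the source may have more. Where it says the series, first, only, none or still open, it means among the compounds named here.

Measured compounds:
- compound 1 `Cc1ccc(CC(CNC(=S)N(O)Cc2ccc(NS(C)(=O)=O)cc2)COC(=O)C(C)(C)C)cc1C`, in an assay on CHO cells for binding affinity to transient receptor potential cation channel subfamily V member 1 (Rattus norvegicus) (a higher number here means a weaker inhibitor, a lower number a stronger inhibitor), compound 1 gives 481 nM
- compound 2 `Cc1ccc(CC(CNC(=S)OCc2ccc(NS(C)(=O)=O)cc2)COC(=O)C(C)(C)C)cc1C`, in this assay compound 2 gives 336 nM

Going by the values given here, compound 2 has the lowest of the two numbers so far, but its nearest neighbour, compound 1, lies within the scatter, so no order between compound 2 and compound 1 can be read from these two values.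

Compound 3 `Cc1ccc(CC(CNC(=S)OCc2ccc(NS(C)(=O)=O)c(F)c2)COC(=O)C(C)(C)C)cc1C` is the next member and has not yet been measured in this assay. It differs from compound 2 in one place: fluoro in place of hydrogen on an aromatic carbon. Among the compounds with values here, the change is small and no pair of measured compounds shows what such a change does, so any expectation rests on the size of the change alone. A modest step is expected, in the direction of a lower number, beyond the scatter but not large. For compound 3 the expected value in this assay is 120 nM, with a range from 40 nM to 350 nM. The estimated step from compound 2 to compound 3 is a 2.8-fold lower number from compound 2 to compound 3 (0.45 log units; beyond the scatter).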

Compound 3, inhibition constant: 210 nM
Compound 3: the middle estimate sits 1.8-fold (0.24 log units) below what was measured; low and high end bracket the measured number.
By their numbers in this assay, from the lowest: compounds 3, 2 and 1 (each within the scatter of the next, the first and the last beyond it).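

In this assay, going by these compounds alone, fluoro in place of hydrogen ortho to the methanesulfonamido group gives a 1.6-fold lower number from compound 2 to compound 3 (0.20 log units; within the scatter) and this is the first one-place step. This position therefore accepts a fluoro group with no readable shift in the number, and no order can be set between compound 2 and compound 3. No measurement here offers an explanation for this outcome.

Going by these compounds, whether a larger group on the same aromatic carbon, such as chloro, methoxy or trifluoromethyl, would move the number beyond the scatter remains open. Within the data shown here, also open is whether a fluoro at this place on compound 1, with its N-hydroxy thiourea link, would give a step like the one seen on compound 2.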